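The source may report more compounds than this note shows. Statements on the series, on what has been measured and on what is new or still open speak of the compounds shown alone.

Compound 1 `COC(=O)[C@@H](C)NC(=O)Cn1cc(C2=C(c3c[nH]c4ccccc34)C(=O)N(C)C2=O)c2ccccc21`: 15300 nM
Compound 2 `COC(=O)[C@H](NC(=O)Cn1cc(C2=C(c3c[nH]c4ccccc34)C(=O)N(C)C2=O)c2ccccc21)C(C)C`: 16000 nM
Compound 3 `COC(=O)[C@@H](CO)NC(=O)Cn1cc(C2=C(c3c[nH]c4ccccc34)C(=O)N(C)C2=O)c2ccccc21`: 24500 nM

These three compounds share one core and differ only in the group carried on the saturated chain carbon bound to an amide-type nitrogen and a carbonyl carbon. In a functional assay on MCF7 cells (Homo sapiens) for cytotoxicity, read by MTT assay, with a stated time of 24 h (on this read-out higher numbers stand for weaker inhibition and lower numbers for stronger inhibition), compound 3 stands highest of the three numbers shown, but the margins are small: a 1.6-fold higher number from compound 1 to compound 3 (0.20 log units; within the scatter) and a 1.5-fold higher number from compound 2 to compound 3 (0.19 log units; within the scatter), both within the scatter, as is a 1.0-fold higher number from compound 1 to compound 2 (0.02 log units; within the scatter). In short, none of the three changes at this place moved the number in a way that can be told apart from repeat measurements.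

Compound 4 `COC(=O)CC[C@@H](NC(=O)Cn1cc(C2=C(c3c[nH]c4ccccc34)C(=O)N(C)C2=O)c2ccccc21)C(=O)OC` has not yet been measured. It differs from compound 3 by (methoxycarbonyl)methyl in place of hydroxy on a saturated chain carbon, two bonds along the chain from an amide-type nitrogen and a carbonyl carbon. The measured steps that bear on this change are the three swaps of side groups at the same place described above, and all of them stayed within the scatter. On that basis the step from compound 3 to compound 4 is expected to be a 1.4-fold lower number from compound 3 to compound 4 (0.13 log units; within the scatter), with no shift beyond the scatter in either direction. For compound 4 the value in this assay is therefore estimated at 18000 nM, with a likely range from 9000 nM to 36000 nM.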

Compound 4, half-maximal inhibitory concentration: 23400 nM
For compound 4 the middle estimate is 1.3-fold (0.11 log units) below the measured one; measured number inside the range.
By their numbers in this assay, from the lowest: compounds 1, 2, 4 and 3 (each within the scatter of the next).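

Compound 4 brings a much bigger change to this place than the earlier swaps: (methoxycarbonyl)methyl, with 5 heavy atoms and a second ester carbonyl, replaces hydroxy, with 1 heavy atom and a hydrogen-bond donor, yet this assay gives a 1.0-fold lower number from compound 3 to compound 4 (0.02 log units; within the scatter). The comparisons with the two side groups lacking hydroxy or ester also stay unresolved, at a 1.5-fold higher number from compound 2 to compound 4 (0.17 log units; within the scatter) and a 1.5-fold higher number from compound 1 to compound 4 (0.18 log units; within the scatter), so methyl, isopropyl, hydroxymethyl and 2-(methoxycarbonyl)ethyl all sit within the scatter of one another, and adding a longer ester-bearing chain at this place does not separate compound 4 from the other three. No measurement is available here that could explain why the number stays so flat across these side groups.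

From the compounds shown here alone, all four side groups carry no net charge and no ring, so it remains open whether a primary amine, a free carboxylic acid or a benzyl group at this place would finally move the number beyond the scatter. The methyl ester is also common to all four compounds, which leaves the effect of a free carboxylic acid or a simple amide in its place unknown.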